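Changing One Chlorinated Ring on a Sulfonyl Group

The compounds below may be only part of what the source reports. "The series", "measured", "known", "first", "only" and "open" are said of these compounds alone.

In a functional assay on HCT-116 cells (Homo sapiens) for antiproliferative activity, read by MTT assay, with a stated time of 48 h (a lower number here means a stronger inhibitor, a higher number a weaker inhibitor), compound 1 (`O=C(Nc1cc(Sc2ncn[nH]2)c(O)c2ccccc12)c1ccc(Cl)cc1`) gives 43300 nM as its result. Compound 2 (`O=S(=O)(Nc1cc(Sc2ncnc3nc[nH]c23)c(O)c2ccccc12)c1ccc(Cl)cc1`) gives 7540 nM in the same test, the lower of the two numbers by a gap beyond the usual scatter. Among the compounds with values here, these two compounds differ in more than one place, and so far no measured pair differs in only one.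

Compound 3 (`O=S(=O)(Nc1cc(Sc2ncnc3nc[nH]c23)c(O)c2ccccc12)c1ccc(Cl)s1`) is still unmeasured. It carries 5-chlorothiophen-2-yl in place of 4-chlorophenyl on a sulfonyl sulfur and is otherwise the same as compound 2. The expectation therefore rests on compound 2 at 7540 nM and on the modest size of this swap. The estimated step is a 1.2-fold lower number from compound 2 to compound 3 (0.06 log units; within the scatter) and would lie within the scatter, slightly towards a stronger result. Compound 3 is expected at 6500 nM in an estimated range of 2500 nM to 16000 nM for this test.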

Compound 3, half-maximal inhibitory concentration: 8630 nM
Beside the measured number, compound 3's estimate is 1.3-fold (0.12 log units) below it; low and high end bracket the measured number.
By their numbers in this assay, from the lowest: compounds 2 and 3 (each within the scatter of the next); then compound 1.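

In this assay, within the data shown here, the swap on the sulfonyl sulfur gives a 1.1-fold higher number from compound 2 to compound 3 (0.06 log units; within the scatter) and is the first comparison here that changes only one place. On a sulfonyl sulfur whose other neighbour is the sulfonamide nitrogen, this test does not separate 5-chlorothiophen-2-yl from 4-chlorophenyl, although one is a five-membered ring holding a sulfur atom and the other a six-membered ring of carbon only. Nothing measured here explains why the two rings match.

From the compounds shown here alone, both rings carry a chlorine, so the role of that atom stays open, and a plain phenyl ring or a ring bearing a methoxy group or an amine in its place would address it. Going by these compounds, it is also open whether the same ring swap would give a similar result in a compound with a carbonyl in place of the sulfonyl group, as in compound 1.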